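The source may report more compounds than this note shows. Statements on the series, on what has been measured and on what is new or still open speak of the compounds shown alone.

Compound 1 `COc1ccc(N(C)c2ccnc(Cl)n2)cc1F`: 914 nM
Compound 2 `COc1ccc(N(C)c2ccnc(Cl)n2)cc1Cl`: 1170 nM
Compound 3 `COc1ccc(N(C)c2ccnc(Cl)n2)cc1OCCCBr`: 1970 nM

These values come from a functional assay on HCT-116 cells (Homo sapiens) for antiproliferative activity, read by MTT assay, with a stated time of 48 h; a higher number here means a weaker inhibitor, a lower number a stronger inhibitor. Compound 3 sits at the upper end of this small set, though it is not clearly apart from every other compound: the two steps are a 2.2-fold higher number from compound 1 to compound 3 (0.33 log units; beyond the scatter) and a 1.7-fold higher number from compound 2 to compound 3 (0.23 log units; within the scatter).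

Compound 4 `COc1ccc(N(C)c2ccnc(Cl)n2)cc1OCCCCBr` differs from compound 3 as follows: bromomethyl in place of bromo on a saturated chain carbon, three bonds along the chain from an oxygen on an aromatic ring. Put another way, 3-bromopropyl gives way to 4-bromobutyl. Going by the values given here, no measured step changes only this chain, so the evidence is indirect. Even replacing a halogen with the whole 3-bromopropoxy group gave only a 2.2-fold higher number from compound 1 to compound 3 (0.33 log units; beyond the scatter) and a 1.7-fold higher number from compound 2 to compound 3 (0.23 log units; within the scatter). A step beyond the scatter in this assay is therefore not expected, in either direction. Compound 4 is estimated at 2000 nM, with an expected range of 1000 nM to 3900 nM.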

Compound 4, half-maximal inhibitory concentration: 1140 nM
Beside the measured number, compound 4's estimate is 1.8-fold (0.24 log units) above it; measured number inside the range.
By their numbers in this assay, from the lowest: compounds 1, 4, 2 and 3 (each within the scatter of the next, the first and the last beyond it).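

In this assay this chain can grow without a clear effect: 3-bromopropyl giving way to 4-bromobutyl stays within the scatter (a 1.7-fold lower number from compound 3 to compound 4 (0.24 log units; within the scatter)). The whole 4-bromobutoxy group also stays within the scatter when it stands in place of chloro (a 1.0-fold lower number from compound 2 to compound 4 (0.01 log units; within the scatter)) and in place of fluoro (a 1.2-fold higher number from compound 1 to compound 4 (0.10 log units; within the scatter)). No supporting evidence bears on why these steps are so small. Still open, going by these compounds, is whether a chain longer than 4-bromobutyl, or an amine or a carboxylic acid in place of the bromo, would read the same.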